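Methoxyphenyl ether in place of the dichlorophenyl ether

The source may hold more compounds than are shown below. What is called first, only, known or untested is meant among the compounds shown, and "the series" means these compounds.

Three aryl ethers on the shared core have numbers in a functional assay on HL-60 cells (Homo sapiens) for antiproliferative activity, read by MTT assay, with a stated time of 72 h; on this read-out lower numbers stand for stronger inhibition and higher numbers for weaker inhibition. Compound 1 `NC1=NC2(CCOCC2)N(OCCCOc2ccc(F)cc2)C(N)=N1` gives 2380 nM, compound 2 `Cc1ccc(OCCCON2C(N)=NC(N)=NC23CCOCC3)cc1` gives 2580 nM, and compound 3 `NC1=NC2(CCOCC2)N(OCCCOc2cccc(Cl)c2Cl)C(N)=N1` gives 440 nM, the lowest of the three; its nearest neighbour on the numbers is compound 1 and its furthest is compound 2. The step of a 5.4-fold lower number from compound 1 to compound 3 (0.73 log units; beyond the scatter) and the step of a 5.9-fold lower number from compound 2 to compound 3 (0.77 log units; beyond the scatter) run in the same direction, while the step of a 1.1-fold higher number from compound 1 to compound 2 (0.04 log units; within the scatter) stays within the scatter.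

Compound 4 `COc1ccc(OCCCON2C(N)=NC(N)=NC23CCOCC3)cc1` differs from compound 3 in one place: 4-methoxyphenyl in place of 2,3-dichlorophenyl on an oxygen on a saturated carbon. The entering 4-methoxyphenyl belongs with the 4-fluorophenyl of compound 1 and the 4-methylphenyl of compound 2 rather than with the 2,3-dichlorophenyl of compound 3, and those two groups gave numbers within the scatter of each other in this assay. The change is therefore expected to undo the gain seen in a 5.4-fold lower number from compound 1 to compound 3 (0.73 log units; beyond the scatter) and a 5.9-fold lower number from compound 2 to compound 3 (0.77 log units; beyond the scatter). Compound 4 is expected to move back toward that region by a step estimated as a 5.0-fold higher number from compound 3 to compound 4 (0.70 log units; beyond the scatter). Compound 4 is estimated at 2200 nM, with a range of 900 nM to 5500 nM.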

Compound 4, half-maximal inhibitory concentration: 1670 nM
Compound 4: the middle estimate sits 1.3-fold (0.12 log units) above what was measured; measured number inside the range.
By their numbers in this assay, from the lowest: compound 3; then compounds 4, 1 and 2 (each within the scatter of the next).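

In this assay, the step of a 3.8-fold higher number from compound 3 to compound 4 (0.58 log units; beyond the scatter) shows that compound 3 stays apart from a third aryl ether, and that this holds for a substituent carrying an oxygen as well as for fluoro and methyl. Within the data shown here, the steps of a 1.5-fold lower number from compound 2 to compound 4 (0.19 log units; within the scatter) and a 1.4-fold lower number from compound 1 to compound 4 (0.15 log units; within the scatter) both stay within the scatter, so methoxy, methyl and fluoro on the aromatic carbon cannot be told apart here, and the hydrogen-bond acceptor counted on the 4-methoxyphenyl brings no separable step. No measurement at hand accounts for the separation of compound 3 from the other aryl ethers.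

The compounds shown cannot tell whether the lower number of compound 3 goes with the presence of two chlorines or with where they sit. As far as these compounds go, how an unsubstituted phenyl or a monochlorophenyl group would read at this place remains open.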